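This account rests on a few compounds, and the source may have more. Where it says the series, first, only, none or still open, it means among the compounds named here.

Working notes on the series. Compound 3 `Cc1ccc(-c2nnc(-c3c[nH]c4ncc(-c5ccc(S(C)(=O)=O)cc5)cc4c3=O)o2)cc1` gives 10.6% in a functional assay on MCF7 cells (Homo sapiens) for inhibition, read by MTT assay, with a stated time of 24 h, tested at 10 uM (a lower number here means less inhibition of growth, a higher number more inhibition of growth at the concentration tested), the highest of the three numbers, though within the scatter of both neighbours. Compound 1 `CS(=O)(=O)c1ccc(-c2cnc3[nH]cc(-c4nnc(-c5ccncc5)o4)c(=O)c3c2)cc1` gives 4.27% and compound 2 `CS(=O)(=O)c1ccc(-c2cnc3[nH]cc(-c4nnc(-c5ccccc5)o4)c(=O)c3c2)cc1` gives 2.83% in this assay. Compound 4 `Cc1cccc(-c2nnc(-c3c[nH]c4ncc(-c5ccc(S(C)(=O)=O)cc5)cc4c3=O)o2)c1` differs from compound 3 by 3-methylphenyl in place of 4-methylphenyl on an aromatic carbon. Within the data shown here, the steps that bear on this place are a number 6.3 percentage points higher from compound 1 to compound 3 (within the scatter) and a number 7.8 percentage points higher from compound 2 to compound 3 (within the scatter), both within the scatter, as is a number 1.4 percentage points lower from compound 1 to compound 2 (within the scatter); every change of the aryl group at this carbon so far has left this assay unmoved beyond the scatter. For compound 4 the expected step is therefore a number 1.6 percentage points lower from compound 3 to compound 4 (within the scatter), no real movement, and the estimate is 9%, with a range of 1% to 20%.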

Compound 4, percent growth inhibition at one concentration: 7.76%
For compound 4 the middle estimate is 1.2 percentage points above the measured one; measured number inside the range.
By their numbers in this assay, from the lowest: compounds 2, 1, 4 and 3 (each within the scatter of the next).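

Exchanging 4-methylphenyl for 3-methylphenyl gives a number 2.8 percentage points lower from compound 3 to compound 4 (within the scatter) in this assay, so this position now has a test of where the methyl sits on the aryl ring, not only of whether it is present, and the step stays within the scatter. The steps to compound 4 from the other two compounds, (a number 4.9 percentage points higher from compound 2 to compound 4 (within the scatter)) and (a number 3.5 percentage points higher from compound 1 to compound 4 (within the scatter)), also stay within the scatter. No supporting measurement accounts for any of these steps.

As far as these compounds go, the effect of an amine or a carboxylic acid on this aryl ring in this assay remains open. Also open, from the compounds shown here alone, is whether any change at this carbon can move the number beyond the scatter.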